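Pyrrolidine in Place of an Arylamine: Expected Loss of Cytotoxicity

The source may report more compounds than this note shows. Statements on the series, on what has been measured and on what is new or still open speak of the compounds shown alone.

Measured compounds:
- compound 1, `O=C(Nc1cc(C(F)(F)F)ccc1N1CCCCC1)c1cccnc1Cl`: "not active" (no number reported)
- compound 2, `O=C(Nc1cc(C(F)(F)F)ccc1Nc1ccc(Br)cc1)c1ccccc1`: 33800 nM

Within the data shown here, in a functional assay on Jurkat cells (Homo sapiens) for cytotoxicity, read by MTT assay, with a stated time of 48 h (a lower number here means a stronger inhibitor, a higher number a weaker inhibitor), compound 2 gives 33800 nM, the only number reported in this assay. Compound 1 is reported in this assay only as "not active" (no number reported), without a number. Compound 3, `O=C(Nc1cc(C(F)(F)F)ccc1N1CCCC1)c1ccccc1`, has not been measured. The change from compound 2 to compound 3 is pyrrolidin-1-yl in place of (4-bromophenyl)amino on an aromatic carbon. Compound 1 carries a saturated nitrogen ring at the same position and is not active, and compound 2 with the (4-bromophenyl)amino group is itself weak in this assay, so the step from compound 2 to compound 3 is expected to be a 2.4-fold higher number from compound 2 to compound 3 (0.37 log units; beyond the scatter), toward weaker inhibition, with a real chance that no number is obtained. For compound 3 the estimate in this assay is 80000 nM, in the range 25000 nM to 300000 nM.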

Compound 3, half-maximal inhibitory concentration: "not active" (no number reported)
Compound 3: no number reported, and the estimate cannot be compared.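

Among these compounds, compound 3 is reported in this assay only as "not active", like compound 1, so no step from compound 2 to compound 3 can be read. The compounds shown leave open how large the difference between compound 2 and compound 3 is. No available evidence bears on this result.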